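Removing the methoxy from a bis-indolyl dibromoquinone

This account rests on a few compounds, and the source may have more. Where it says the series, first, only, none or still open, it means among the compounds named here.

Compound 1 `Cc1ccc(-c2[nH]c3ccccc3c2C2=C(Br)C(=O)C(Br)=C(Br)C2=O)cc1`, compound 2 `Cc1[nH]c2ccccc2c1C1=C(Br)C(=O)C(c2c(C)[nH]c3ccccc23)=C(Br)C1=O` and compound 3 `COc1ccc2[nH]c(C)c(C3=C(Br)C(=O)C(c4c(-c5ccccc5)[nH]c5ccccc45)=C(Br)C3=O)c2c1` share a brominated quinone core bearing indolyl groups. In a functional assay on MCF7 cells (Homo sapiens) for antiproliferative activity, read by CCK-8 assay, with a stated time of 48 h (on this read-out lower numbers stand for stronger inhibition and higher numbers for weaker inhibition), compound 1 reached only the assay limit of > 25 ug/mL, which is a limit and not a number (the limit of > 25 ug/mL in this assay, at which 1 of the 3 values shown sits). Compound 2 gives 7 ug/mL in this assay. Compound 3 gives 2.57 ug/mL, the lowest of the two numbers, with compound 2 the nearest at a higher value beyond the scatter. Compound 4 `Cc1[nH]c2ccccc2c1C1=C(Br)C(=O)C(c2c(-c3ccccc3)[nH]c3ccccc23)=C(Br)C1=O` differs from compound 3 by hydrogen in place of methoxy on an aromatic carbon. For the measured compounds named here, no measured pair shows this change. A small step toward a higher number, likely within the scatter, is expected a 1.6-fold higher number from compound 3 to compound 4 (0.19 log units; within the scatter). Compound 4 is estimated at 4 ug/mL, between 1.5 ug/mL and 10 ug/mL.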

Compound 4, half-maximal inhibitory concentration: 3.02 ug/mL
Estimate against measurement, compound 4: 1.3-fold (0.12 log units) above, and the stated range covers the measured number.
By their numbers in this assay, from the lowest: compounds 3 and 4 (each within the scatter of the next); then compound 2. At a limit, above all of these: compound 1.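

In this assay, going from 5-methoxy-2-methyl-1H-indol-3-yl to 2-methyl-1H-indol-3-yl gives a 1.2-fold higher number from compound 3 to compound 4 (0.07 log units; within the scatter) and so shows that the number holds without the methoxy at this position. Of the two single changes, only phenyl in place of methyl lies beyond the scatter, with a 2.3-fold lower number from compound 2 to compound 4 (0.37 log units; beyond the scatter) as its step. Nothing measured here gives a cause for either step. The compounds shown leave open whether an amine or a carboxylic acid in place of the methoxy would keep the number. They also leave open whether a longer chain in place of the phenyl would keep it.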